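The compounds below may be only part of what the source reports. "The series", "measured", "known", "first", "only" and "open" are said of these compounds alone.

For the measured compounds named here, compound 3 `Cc1nc(N)c2c(-c3cc4ccccc4o3)cn([C@@H]3O[C@H](CO)[C@@H](O)[C@H]3O)c2n1` is the one member of this set with a number rather than a limit in a functional assay on CEM-DNR-bulk cells (Homo sapiens), read by MTT assay, with a stated time of 72 h; a higher number here means a weaker inhibitor, a lower number a stronger inhibitor: compound 3 gives 6310 nM. Compound 1 `Nc1nc(N)c2c(-c3cc4ccccc4o3)cn([C@@H]3O[C@H](CO)[C@@H](O)[C@H]3O)c2n1` stands at a limit of the assay, as compound 1 gives > 20000 nM. Compound 2 `COc1ncnc2c1c(-c1ccccc1)cn2[C@@H]1O[C@H](CO)[C@@H](O)[C@H]1O` likewise stands at a limit, since compound 2 gives > 20000 nM. Going by the values given here, the one measured step, an at least 3.1-fold lower number from compound 1 to compound 3 (0.50 log units; beyond the scatter), rests on the fact that (the limit of > 20000 nM in this assay, at which 2 of the 3 values shown sit), so its true size is not known beyond its lower bound.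

Compound 4 `Cc1nc(N)c2c(-c3cccs3)cn([C@@H]3O[C@H](CO)[C@@H](O)[C@H]3O)c2n1` differs from compound 3 in one place: thiophen-2-yl in place of 1-benzofuran-2-yl on an aromatic carbon. Among the compounds with values here, no measured step in this assay touches this position, so no step bears directly on the change; the step from compound 1 to compound 3 concerns the other aromatic carbon and only shows that the number can move beyond the scatter within this core. Compound 2 carries a phenyl group at the corresponding position, but it differs from compound 3 in more than one place, so only its limit can be noted. With the smaller thiophen-2-yl group entering, the expectation for compound 4 is a weaker inhibitor, a step of a 2.4-fold higher number from compound 3 to compound 4 (0.38 log units; beyond the scatter), and a fair chance that only a limit is reported. Compound 4 is therefore estimated at 15000 nM, within a range from 5000 nM to 40000 nM.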

Compound 4, half-maximal inhibitory concentration: > 20000 nM
Compound 4: no number, only a limit; the forecaster's own chance of this, stated with the estimate: 45%; middle value at least 1.3-fold (0.12 log units) away from the limit.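

In this assay the group on this carbon now has a step of its own: thiophen-2-yl in place of 1-benzofuran-2-yl gives an at least 3.1-fold higher number from compound 3 to compound 4 (0.50 log units; beyond the scatter) with the methyl group on the other aromatic carbon held fixed. The earlier compounds shown here showed a change beyond the scatter only at that other aromatic carbon, whereas this result shows that the number also depends on the group here, and that the number of compound 3 is not kept when the six-membered aromatic ring of carbon only is lost and the group falls from 9 heavy atoms to 5. Going by these compounds, compound 4 gives > 20000 nM as a limit and not a number, so the step is only a lower bound and its true size is unknown: the limit of > 20000 nM in this assay, at which 3 of the 4 values shown sit.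

The compounds shown leave open whether the fused six-membered ring or the oxygen in place of sulfur accounts for the step, as the two change together. A furan-2-yl or a 1-benzothiophen-2-yl group on this carbon, with the rest of compound 3 unchanged, would separate the two.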